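From Methoxycarbonyl to Hydroxymethyl on the Side Chain

The source may hold more compounds than are shown below. What is called first, only, known or untested is meant among the compounds shown, and "the series" means these compounds.

In a functional assay on the whole organism with Rattus norvegicus as the target (on this read-out lower numbers stand for an effect already at smaller amounts and higher numbers for an effect only at larger amounts of compound), compound 3 (`COC(=O)Cn1c(=N)sc2cc(OC(F)(F)F)ccc21`) gives > 10 mg/kg, which is a limit of the assay and not a number. Compound 3 alone stands at the limit of > 10 mg/kg in this assay, at which 1 of the 3 values shown sits. Compound 1 (`CCn1c(=N)sc2cc(OC(F)(F)F)ccc21`) gives 5 mg/kg and compound 2 (`C#CCn1c(=N)sc2cc(OC(F)(F)F)ccc21`) gives 4 mg/kg, and a 1.3-fold lower number from compound 1 to compound 2 (0.10 log units; within the scatter) separates them.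

Compound 4 (`N=c1sc2cc(OC(F)(F)F)ccc2n1CCO`) carries hydroxymethyl in place of methoxycarbonyl on a saturated chain carbon bound to an aromatic nitrogen. Among the measured compounds shown here, two measured steps bear on this change. They introduce the group now leaving. Methoxycarbonyl in place of methyl gave an at least 2.0-fold higher number from compound 1 to compound 3 (0.30 log units; that floor lies within the scatter), and methoxycarbonyl in place of ethynyl gave an at least 2.5-fold higher number from compound 2 to compound 3 (0.39 log units; beyond the scatter). Going by these compounds, both are floors, so their full size is unknown, and hydroxymethyl itself has not been measured on this core. Removing methoxycarbonyl should therefore recover part of that loss, though perhaps not all of it. The expected result is a modest move to a lower number, an at least 1.2-fold lower number from compound 3 to compound 4 (0.09 log units; that floor lies within the scatter). For compound 4 the estimate in this assay is 8 mg/kg, with an expected range from 3 mg/kg to 20 mg/kg.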

Compound 4, dose for half-maximal effect: 8 mg/kg
Beside the measured number, compound 4's estimate shows no gap at the digits printed; the range from low to high includes it.
By their numbers in this assay, from the lowest: compounds 2, 1 and 4 (each within the scatter of the next). At a limit, above all of these: compound 3.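

Hydroxy in place of hydrogen on the chain, two bonds along from an aromatic nitrogen, brought no shift that stands out from the scatter in this assay (a 1.6-fold higher number from compound 1 to compound 4 (0.20 log units; within the scatter)). The same holds against the ethynyl side chain (a 2.0-fold higher number from compound 2 to compound 4 (0.30 log units; within the scatter)), so this position accepts the 2-hydroxyethyl group, with its hydrogen-bond donor, alongside the two chains that carry none. Among the compounds shown here, the exchange for methoxycarbonyl can be stated only as a floor that lies within the scatter (an at least 1.2-fold lower number from compound 3 to compound 4 (0.09 log units; that floor lies within the scatter)), and compound 3 remains the one compound held at a limit of the assay: the limit of > 10 mg/kg in this assay, at which 1 of the 4 values shown sits.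

Going by these compounds, the size of that exchange therefore stays open. Also open, on these data alone, is whether a carboxylic acid, an amine or a longer chain at this place would stay level with compound 4.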